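This account rests on a few compounds, and the source may have more. Where it says the series, first, only, none or still open, it means among the compounds named here.

Of the compounds shown here, three have been measured in an assay on membranes from HEK293 cells for displacement of a labelled ligand from adenosine receptor A2b (Homo sapiens), read by scintillation counting, with a stated time of 30 min; a lower number here means a stronger inhibitor, a higher number a weaker inhibitor: compound 1 `CC1=C(C(=O)CC(C)C)C(c2ccco2)NC(=O)N1` gives 240 nM, compound 2 `CC1=C(C(=O)CC(C)C)C(c2ccoc2)NC(=O)N1` gives 1010 nM, and compound 3 `CCC(C)OC(=O)C1=C(C)NC(=O)NC1c1ccco1` gives 84.3 nM.

Two steps stand out. The change furan-3-yl in place of furan-2-yl on a saturated ring carbon produced a 4.2-fold higher number from compound 1 to compound 2 (0.62 log units; beyond the scatter). The change sec-butoxy in place of isobutyl on a carbonyl carbon produced a 2.8-fold lower number from compound 1 to compound 3 (0.45 log units; beyond the scatter), leaving compound 3 with the lowest number of the three.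

Compound 4 `CCC(C)OC(=O)C1=C(C)NC(=O)NC1c1ccoc1` is not yet measured. It differs from compound 3 by furan-3-yl in place of furan-2-yl on a saturated ring carbon, the same kind of change as that from compound 1 to compound 2, though here the place lies next to the ring atom that bears a group of 7 heavy atoms rather than an isobutylcarbonyl group (6 heavy atoms). Because the earlier step was a 4.2-fold higher number from compound 1 to compound 2 (0.62 log units; beyond the scatter), a step of similar size, a 4.2-fold higher number from compound 3 to compound 4 (0.62 log units; beyond the scatter), is expected in this assay. On that basis compound 4 is estimated at 350 nM, between 150 nM and 900 nM.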

Compound 4, inhibition constant: 201 nM
Compound 4: middle estimate off by 1.7-fold (0.24 log units), on the high side, within the range that was stated.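

In this assay, furan-3-yl in place of furan-2-yl on a saturated ring carbon gave a 2.4-fold higher number from compound 3 to compound 4 (0.38 log units; beyond the scatter), and this step agrees with its earlier counterpart: the same change on two cores in this assay, a 4.2-fold higher number (0.62 log units; beyond the scatter) from compound 1 to compound 2 and a 2.4-fold higher number (0.38 log units; beyond the scatter) from compound 3 to compound 4, 1.8-fold (0.25 log units) apart, within the scatter of two such steps. Sec-butoxy in place of isobutyl on a carbonyl carbon gave a 5.0-fold lower number from compound 2 to compound 4 (0.70 log units; beyond the scatter), and this change also carried over: the same change on two cores in this assay, a 2.8-fold lower number (0.45 log units; beyond the scatter) from compound 1 to compound 3 and a 5.0-fold lower number (0.70 log units; beyond the scatter) from compound 2 to compound 4, 1.8-fold (0.25 log units) apart, within the scatter of two such steps. Each change thus kept its direction across the two cores shown, with no difference in size beyond the scatter, but a single pair of steps per change does not show that either would carry over to other cores, nor why they carried over here.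

As far as these compounds go, it remains open how a thiophene or phenyl ring would compare with the furans on the saturated ring carbon. From the compounds shown here alone, it is also open whether a longer alkoxy chain or an amine on the carbonyl carbon would extend the trend seen with sec-butoxy.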